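The source may hold more compounds than are shown below. What is called first, only, known or untested is meant among the compounds shown, and "the series" means these compounds.

Compound 1, `CN(Cc1ccc2nccn2c1)c1nnc(-c2ccc(C3CC3)cc2)o1`: in a physicochemical assay for lipophilicity, at pH 7.4 (on this read-out lower numbers stand for lower lipophilicity and higher numbers for higher lipophilicity), compound 1 gives 3.5
Compound 2, `COc1ccccc1-c1ccc(-c2nnc(N(C)Cc3ccc4nccn4c3)o2)cc1`: compound 2 gives 4.1
Compound 3, `Cc1nn(C)c(C)c1-c1ccc(-c2nnc(N(C)Cc3ccc4nccn4c3)o2)cc1`: compound 3 gives 3.1

Compound 3 stands lowest of the three numbers: the steps of a number 0.40 log units lower from compound 1 to compound 3 (beyond the scatter) and a number 1.00 log units lower from compound 2 to compound 3 (beyond the scatter) both end on it. Compound 4, `Cc1nn(C)c(C)c1-c1ccc(-c2nnc(N(C)Cc3ccc4nccn4c3)o2)c(F)c1`, differs from compound 3 by fluoro in place of hydrogen on an aromatic carbon. Among the measured compounds shown here, none of the measured steps swaps a hydrogen for a fluoro; each of them exchanges the whole group on the far ring, so they set the spread of the series but do not bear on this change directly. For compound 4 a step of a number 0.20 log units higher from compound 3 to compound 4 (within the scatter) is therefore expected, a small rise at most, likely within the scatter. Compound 4 is estimated at 3.3, with a range from 3 to 3.6.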

Compound 4, distribution coefficient: 3.2
Compound 4: middle estimate off by 0.10 log units, on the high side; the measured number falls inside the stated range.
By their numbers in this assay, from the lowest: compounds 3, 4 and 1 (each within the scatter of the next, the first and the last beyond it); then compound 2.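

In this assay, fluoro in place of hydrogen on an aromatic carbon, ortho to a large group, gives a step (a number 0.10 log units higher from compound 3 to compound 4 (within the scatter)), so this exchange does not separate the two compounds. Among the compounds shown here, the earlier steps each exchanged a whole group, and this is the first reading of a single fluoro at this position. No measurement shown here offers an explanation for the result. The compounds shown leave open whether an amine or a carboxylic acid at this position would shift the number. They also leave open whether fluoro gives the same result alongside the cyclopropyl or 2-methoxyphenyl groups.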